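Adding a bulky group to the most active hydroxy compound

A few compounds are considered here, and "the series" means these few. Any claim that something is new, unique, unknown or untested is made for them only; others in the source may bear on it.

compound 1 `COc1ccc(OC)c(C2=C(c3cc(OC)c(OC)c(OC)c3)C(=O)CC2O[SiH2]C(C)(C)C)c1`: 5 ug/mL
compound 2 `COc1ccc(C2=C(c3cc(OC)c(OC)c(OC)c3)C(=O)CC2O)cc1O`: < 1 ug/mL (a limit, not a number)
compound 3 `COc1ccc(C2=C(c3cc(OC)c(OC)c(OC)c3)C(=O)CC2O)cc1`: 15 ug/mL

All three values come from an ADME assay on HT-29 cells (Homo sapiens) for cytotoxicity, read by MTT assay, with a stated time of 72 h; on this read-out lower numbers stand for stronger inhibition and higher numbers for weaker inhibition. Compound 2 stands at the limit of < 1 ug/mL in this assay, at which 1 of the 3 values shown sits, so its position is known only as a limit.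

Compound 4 `COc1ccc(C2=C(c3cc(OC)c(OC)c(OC)c3)C(=O)CC2O[SiH2]C(C)(C)C)cc1O` is compound 2 with a single change: a group of 5 heavy atoms (4 carbon, 1 silicon; no ring) in place of a hydrogen atom, on an oxygen on a saturated carbon. The group sits on an oxygen on a saturated carbon. Going by the values given here, no measured step covers this exact change.

Among the compounds with values here, the one measured step, an at least 15-fold higher number from compound 2 to compound 3 (1.17 log units; beyond the scatter), is large, but it concerns hydrogen in place of hydroxy on an aromatic carbon, which is a different change. Compound 4 keeps that hydroxy group, so the expectation is that it stays on the favourable side of an at least 15-fold higher number from compound 2 to compound 3 (1.17 log units; beyond the scatter).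

Compound 1 carries the same group on a differently substituted core and gives 5 ug/mL. This is only a loose guide, since it differs from compound 4 in more than one respect.

A modest move towards a higher number, meaning weaker inhibition, is therefore expected in this assay, and the estimated size is an at least 2.0-fold higher number from compound 2 to compound 4 (0.30 log units; that floor lies within the scatter). For compound 4 the estimated value is 2 ug/mL, with an expected range of 0.4 ug/mL to 8 ug/mL.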

Compound 4, half-maximal inhibitory concentration: 38 ug/mL
Beside the measured number, compound 4's estimate is 19-fold (1.28 log units) below it, outside the stated range (above it).
By their numbers in this assay, from the lowest: compound 1; then compound 3; then compound 4. At a limit, below all of these: compound 2.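

In this assay, replacing the hydrogen on the oxygen on a saturated carbon with the silicon-containing group is far from a mild change, with a step of an at least 38-fold higher number from compound 2 to compound 4 (1.57 log units; beyond the scatter). Compound 2 is known only as a limit, so this step is a floor and the true size cannot be read: the limit of < 1 ug/mL in this assay, at which 1 of the 4 values shown sits. With the group present, the hydroxy on the aromatic ring no longer secures a low number, as 3-hydroxy-4-methoxyphenyl in place of 2,5-dimethoxyphenyl gives a 7.6-fold higher number from compound 1 to compound 4 (0.88 log units; beyond the scatter).

As far as these compounds go, it remains open whether the loss belongs to this particular silicon-containing group or to any replacement of that hydrogen, and a small methyl ether or an acetate ester on the same oxygen would help to separate the two. The compounds shown also leave open how 2,5-dimethoxyphenyl behaves with the free hydroxy on the saturated carbon, so these two aromatic rings can be compared only with the silicon-containing group in place.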